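A Sulfonamide Arm Takes the Place of a Decyl Chain

This account rests on a few compounds, and the source may have more. Where it says the series, first, only, none or still open, it means among the compounds named here.

Compound 3 `CCCCCCCCCCc1cn(C[C@H](O)[C@H]2OC(=O)C(OCc3ccccc3)=C2OCc2ccccc2)nn1` carries a decyl chain on its triazole. In an ADME assay on HFF cells (Homo sapiens) for cytotoxicity, read by MTT assay, with a stated time of 72 h (on this read-out higher numbers stand for weaker inhibition and lower numbers for stronger inhibition), compound 3 gives > 100000 nM, which is a limit of the assay and not a number. Compound 2 `CCCCCc1ccc(-c2cn(C[C@H](O)[C@H]3OC(=O)C(OCc4ccccc4)=C3OCc3ccccc3)nn2)cc1` also gives only a limit in this assay, > 100000 nM. Compound 1 `O=C1O[C@H]([C@@H](O)Cn2cc(-c3ccc(Br)cc3)nn2)C(OCc2ccccc2)=C1OCc1ccccc1` gives 5100 nM in this assay. So the steps run an at least 19-fold higher number from compound 1 to compound 2 (1.29 log units; beyond the scatter) and an at least 19-fold higher number from compound 1 to compound 3 (1.29 log units; beyond the scatter), while the step that the two limits leave unreadable from compound 2 to compound 3 because of the limit of > 100000 nM in this assay, at which 2 of the 3 values shown sit. Within the data shown here, compound 3 therefore stands at the limit, together with compound 2, with compound 1 the only measured number below it.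

Compound 4 `O=C1O[C@H]([C@@H](O)Cn2cc(CNS(=O)(=O)c3ccc(Cl)cc3)nn2)C(OCc2ccccc2)=C1OCc1ccccc1` differs from compound 3 by ((4-chlorophenyl)sulfonyl)amino in place of nonyl on a saturated chain carbon bound to an aromatic carbon. Among the measured compounds shown here, none of the measured steps touches a sulfonamide or a chlorophenyl group, so they do not test this change; they only show that two of three compounds sit at the limit. Compound 4 is expected to give about 30000 nM, within 5000 nM to 100000 nM, which means an expected step of an at least 3.3-fold lower number from compound 3 to compound 4 (0.52 log units; beyond the scatter) that the limit on compound 3 cannot fix.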

Compound 4, half-maximal inhibitory concentration: 20 nM
Compound 4: the middle estimate sits 1500-fold (3.18 log units) above what was measured, outside the stated range (below it).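

In this assay, this position proves able to carry a very large gain in inhibition: ((4-chlorophenyl)sulfonyl)amino in place of nonyl gives an at least 5000-fold lower number from compound 3 to compound 4 (3.69 log units; beyond the scatter), and the same arm gives an at least 5000-fold lower number from compound 2 to compound 4 (3.69 log units; beyond the scatter). Among these compounds, the earlier steps all ran toward weaker inhibition, whereas this one runs the other way and also passes the only earlier measured number, with a 260-fold lower number from compound 1 to compound 4 (2.41 log units; beyond the scatter). Only that last step has an exact size, and the other two are minimum sizes because of one shared ceiling: the limit of > 100000 nM in this assay, at which 2 of the 4 values shown sit.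

The change brings in a sulfonyl group, an amino hydrogen and a chlorophenyl ring together, so the compounds shown cannot say which part matters. A carboxamide link in place of the sulfonamide, or an unsubstituted phenyl ring in place of the 4-chlorophenyl, would help to separate them.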